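A few compounds are considered here, and "the series" means these few. Any claim that something is new, unique, unknown or untested is made for them only; others in the source may bear on it.

Measured in a functional assay on SW-620 cells (Homo sapiens) for inhibition, read by sulforhodamine B assay, with a stated time of 48 h; a higher number here means a weaker inhibitor of growth, a lower number a stronger inhibitor of growth:
- Compound 1 `O=C(Nc1cccc(-n2cc(-c3ccncc3)c(-c3ccc(Cl)c(O)c3)n2)c1)Nc1cccc(C(F)(F)F)c1`: > 32500 nM (a limit)
- Compound 2 `COc1cc(-c2nn(-c3cccc(NC(=O)Nc4cc(C(F)(F)F)cc(C(F)(F)F)c4)c3)cc2-c2ccncc2)ccc1Cl`: 1860 nM
- Compound 3 `COc1cc(-c2nn(-c3cccc(NC(=O)c4cccc(C(F)(F)F)c4)c3)cc2-c2ccncc2)ccc1Cl`: > 50000 nM (a limit)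

Among the compounds with values here, only one of these three compounds has a true number. Compound 3 reads > 50000 nM, and this is a limit of this assay, not a number. Its place on the scale is therefore open on one side, and any comparison with it can only be rough.

Compound 4 `COc1cc(-c2nn(-c3cccc(NC(=O)c4ccc(Cl)c(C(F)(F)F)c4)c3)cc2-c2ccncc2)ccc1Cl` is compound 3 with one small change: chloro in place of hydrogen on an aromatic carbon. Chloro takes the place of hydrogen on an aromatic carbon, ortho to a trifluoromethyl group, turning 3-(trifluoromethyl)phenyl into 4-chloro-3-(trifluoromethyl)phenyl.

Within the data shown here, no pair of measured compounds shows what such a change does, so the expectation is loose. Compound 2 gives 1860 nM, which shows that a real number can be obtained among these compounds. On that basis, the expected step, an at least 2.0-fold lower number from compound 3 to compound 4 (0.30 log units; that floor lies within the scatter), is modest and toward stronger growth inhibition, and another limit reading would be no surprise. For compound 4 the estimated value is 25000 nM, with an expected range from 4000 nM to 60000 nM.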

Compound 4, concentration for total growth inhibition: > 32500 nM
Compound 4 ended at the assay's limit; the forecaster's own chance of this, stated with the estimate: 45%; middle value at least 1.3-fold (0.11 log units) away from the limit.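

Within the data shown here, compound 3 and compound 4 both read as limits in this assay, not as numbers, so no step between them can be read. The compounds shown leave open whether chloro in place of hydrogen on an aromatic carbon, turning 3-(trifluoromethyl)phenyl into 4-chloro-3-(trifluoromethyl)phenyl, changes growth inhibition at all.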